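Acetyl in place of methyl in compound 2

A few compounds are considered here, and "the series" means these few. Any claim that something is new, unique, unknown or untested is made for them only; others in the source may bear on it.

In a functional assay on MGC-803 cells (Homo sapiens) for inhibition, read by MTT assay, with a stated time of 48 h (on this read-out lower numbers stand for stronger inhibition and higher numbers for weaker inhibition), compound 2 (`COc1ccc(-c2coc3cc(OCCCSC(=S)N4CCN(C)CC4)ccc3c2=O)cc1`) gives 21900 nM and stands within the scatter of compound 1 (`COc1ccc(-c2coc3cc(OCCCCSC(=S)N4CCN(C(=O)OC(C)(C)C)CC4)ccc3c2=O)cc1`) at 31300 nM and of compound 3 (`COc1ccc(-c2coc3cc(OCCCSC(=S)N4CCN(Cc5ccccc5)CC4)ccc3c2=O)cc1`) at 43800 nM on the same read-out. Compound 4 (`COc1ccc(-c2coc3cc(OCCCSC(=S)N4CCN(C(C)=O)CC4)ccc3c2=O)cc1`) carries acetyl in place of methyl on an amine nitrogen in a ring. For the measured compounds named here, the one measured step that bears on this change is a 2.0-fold higher number from compound 2 to compound 3 (0.30 log units; within the scatter) and it involves a different group. Going by the values given here, compound 1 differs from compound 2 in more than one place and offers no clean step. The expected result is a 1.3-fold higher number from compound 2 to compound 4 (0.11 log units; within the scatter) with no shift beyond the scatter. For compound 4 the estimated value is 28000 nM with an expected range from 12000 nM to 65000 nM in this assay once measured.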

Compound 4, half-maximal inhibitory concentration: 39400 nM
Compound 4: the middle estimate sits 1.4-fold (0.15 log units) below what was measured; measured number inside the range.
By their numbers in this assay, from the lowest: compounds 2, 1, 4 and 3 (each within the scatter of the next).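

In this assay, acetyl in place of methyl on the amine nitrogen in the ring gives a 1.8-fold higher number from compound 2 to compound 4 (0.26 log units; within the scatter), and acetyl in place of benzyl on the same nitrogen gives a 1.1-fold lower number from compound 3 to compound 4 (0.05 log units; within the scatter). With acetyl, which adds a hydrogen-bond acceptor, this position has now carried three groups, and compound 2, compound 3 and compound 4 all stay within the scatter of one another. No supporting evidence bears on this result. The compounds shown leave open whether a hydrogen on this nitrogen, or a carboxylic acid on a longer chain there, would give a number beyond the scatter from compound 2.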